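Swapping the amide tail of a lipopeptide-type receptor agonist

This account rests on a few compounds, and the source may have more. Where it says the series, first, only, none or still open, it means among the compounds named here.

Measured compounds:
Compound 1, `CCCCCCCCCCCC(=O)OC[C@H](CSC[C@@H](N)C(=O)NCCCCCCO)OC(=O)CCCCCCCCCCC`, gives 33 nM in an assay on HEK293 cells for agonist activity at Toll-like receptor 2 (Homo sapiens); on this read-out lower numbers stand for an effect already at smaller amounts and higher numbers for an effect only at larger amounts of compound.
Compound 2, `CCCCCCCCCCCC(=O)OC[C@H](CSC[C@@H](N)C(=O)NCCCC(C)(C)CO)OC(=O)CCCCCCCCCCC`, gives 30700 nM in this assay.
Compound 3, `CCCCCCCCCCCC(=O)OC[C@H](CSC[C@@H](N)C(=O)NCCOCCOS(=O)(=O)O)OC(=O)CCCCCCCCCCC`, gives 61 nM in this assay.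

All three share the same core and differ only in the chain attached to the amide nitrogen. Among the measured compounds shown here, on the numbers so far, compound 3 stands second highest of the three: its step from compound 1, a 1.8-fold higher number from compound 1 to compound 3 (0.27 log units; within the scatter), lies within the scatter, while the gap from compound 2, a 500-fold lower number from compound 2 to compound 3 (2.70 log units; beyond the scatter), is large.

Compound 4, `CCCCCCCCCCCC(=O)OC[C@H](CSC[C@@H](N)C(=O)NC(C)CCc1ccccc1)OC(=O)CCCCCCCCCCC`, has not been measured. Its change from compound 3 is 1-methyl-3-phenylpropyl in place of 2-(2-(sulfooxy)ethoxy)ethyl on an amide-type nitrogen. For the measured compounds named here, the incoming group carries a six-membered aromatic ring and no hydrogen-bond donors or acceptors, so none of the measured steps covers the same kind of exchange. What the measured steps do show is that this position can matter a great deal: a 930-fold higher number from compound 1 to compound 2 (2.97 log units; beyond the scatter), whereas a 1.8-fold higher number from compound 1 to compound 3 (0.27 log units; within the scatter) barely moved the number. Because a 930-fold higher number from compound 1 to compound 2 (2.97 log units; beyond the scatter) shows that a branched replacement at this nitrogen can sharply raise the number, a higher number is expected for compound 4, though with wide uncertainty. The expected step is a 9.8-fold higher number from compound 3 to compound 4 (0.99 log units; beyond the scatter). Compound 4 is estimated at 600 nM, within a range from 60 nM to 8000 nM.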

Compound 4, half-maximal effective concentration: 160 nM
Estimate against measurement, compound 4: 3.8-fold (0.57 log units) above, within the range that was stated.
By their numbers in this assay, from the lowest: compounds 1 and 3 (each within the scatter of the next); then compound 4; then compound 2.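

The result shows that the tail on the amide-type nitrogen needs neither a hydroxyl nor a sulfate ester to keep a low number in this assay. The 1-methyl-3-phenylpropyl group, an all-carbon tail with one six-membered aromatic ring and no hydrogen-bond donors or acceptors, brings only a modest rise against both earlier low compounds (a 2.6-fold higher number from compound 3 to compound 4 (0.42 log units; beyond the scatter); a 4.8-fold higher number from compound 1 to compound 4 (0.69 log units; beyond the scatter)), and it also shows that a branched tail need not cost as much as the 4-(hydroxymethyl)-4-methylpentyl group of compound 2 (a 190-fold lower number from compound 2 to compound 4 (2.28 log units; beyond the scatter)). No measurement at hand explains why these tails differ so much, so the cause of these steps stays unknown.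

The compounds shown leave open what the methyl branch of compound 4 contributes, which a straight 3-phenylpropyl group on the same nitrogen would test. They also leave open whether a tail ending in an amine or a carboxylic acid would stay as low as compound 1 and compound 3, or would climb towards compound 2.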